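From Nitro to Chloro: Expecting a Steady Dose

A few compounds are considered here, and "the series" means these few. Any claim that something is new, unique, unknown or untested is made for them only; others in the source may bear on it.

Of the compounds shown here, three sharing one core have been tested in a functional assay on the whole organism (strain Swiss albino) for inhibition, with Mus musculus as the target, with a stated time of 4 h; on this read-out lower numbers stand for an effect already at smaller amounts and higher numbers for an effect only at larger amounts of compound. Compound 1 `S=c1[nH]nc(Nc2nc(-c3ccc(Cl)cc3)cs2)n1-c1ccccc1` gives 300 mg/kg. Compound 2 `Cc1ccc(-n2c(Nc3nc(-c4ccccc4)cs3)n[nH]c2=S)cc1` gives 300 mg/kg, and compound 3 `Cc1ccc(-n2c(Nc3nc(-c4ccc([N+](=O)[O-])cc4)cs3)n[nH]c2=S)cc1` gives 300 mg/kg. Within the data shown here, compound 3 therefore stands level with compound 1 and compound 2 at the digits reported, and the one step that can be traced, no change at the digits printed from compound 2 to compound 3 (within the scatter), shows that adding a nitro group moved nothing beyond the scatter.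

Compound 4 `Cc1ccc(-n2c(Nc3nc(-c4ccc(Cl)cc4)cs3)n[nH]c2=S)cc1` is the next member. It differs from compound 3 in one place: chloro in place of nitro on an aromatic carbon. Among the measured compounds shown here, no measured step swaps these two groups directly. The step from compound 2 to compound 3 bears on it, since it shows that the group at this position could be changed without moving the read-out, and compound 1, which also carries chloro, gives 300 mg/kg too. So no step beyond the scatter is expected here. Compound 4 is therefore expected to give 300 mg/kg, between 150 mg/kg and 600 mg/kg, which amounts to an expected step of no change at the digits printed from compound 3 to compound 4 (within the scatter).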

Compound 4, minimum effective dose: 300 mg/kg
Compound 4: the middle estimate sits on the measured number at the digits printed; measured number inside the range.
By their numbers in this assay, from the lowest: compounds 1, 2, 3 and 4 (each within the scatter of the next).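

In this assay, chloro in place of nitro gives no change at the digits printed from compound 3 to compound 4 (within the scatter), so the 4-nitrophenyl and 4-chlorophenyl forms read alike. Chloro in place of hydrogen gives no change at the digits printed from compound 2 to compound 4 (within the scatter), and with the earlier nitro step this puts hydrogen, nitro and chloro level with each other on this aromatic carbon. Adding a methyl group gives no change at the digits printed from compound 1 to compound 4 (within the scatter), so the same flat reading now also holds at a second place in the molecule.

No supporting measurement is available to explain these level readings. On these data alone, whether an amine, a carboxylic acid or a longer chain on this aromatic carbon would read differently stays open, and these four compounds offer no step beyond the scatter for comparison.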